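Chloro in Place of Hydrogen: Compound 1 to Compound 4

The source may report more compounds than this note shows. Statements on the series, on what has been measured and on what is new or still open speak of the compounds shown alone.

Compound 1 `CN(C)c1ccc(/C=C2/SC(=Nc3ccccc3)NC2=O)cc1` gives > 100000 nM in an ADME assay on cells (Homo sapiens) for antiproliferative activity (a higher number here means a weaker inhibitor, a lower number a stronger inhibitor), a limit of the assay and not a number.
Compound 2 `CC(=O)Nc1ccc(/C=C2/S/C(=N/c3cccc(Cl)c3)NC2=O)cc1` gives > 100000 nM in this assay, again a limit.
Compound 3 `Cc1ccccc1/N=C1\NC(=O)/C(=C\c2ccc(N(C)C)cc2)S1` gives > 100000 nM in this assay, again a limit.

Compound 1 thus stands at the limit of > 100000 nM in this assay, at which 3 of the 3 values shown sit. For the measured compounds named here, no two of the measured compounds differ in a single place, so no measured step gives the size of any structural change in this assay, and every value shown is a limit rather than a number. Compound 4 `CN(C)c1ccc(/C=C2/SC(=Nc3ccccc3Cl)NC2=O)cc1` is the unmeasured partner of compound 1, and the change between them is chloro in place of hydrogen on an aromatic carbon. The three measured compounds carry different groups on that ring and all sit at the same limit, which leaves no sign that the chloro would move the value. Compound 4 is expected to give 100000 nM, with a range from 30000 nM to 300000 nM, and most probably to be reported again only as a limit. The expected step of a number no higher from compound 1 to compound 4 (the limit leaves the size open) is accordingly none beyond the scatter.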

Compound 4, half-maximal inhibitory concentration: > 100000 nM
Compound 4: no number, only a limit; the forecaster's own chance of this, stated with the estimate: 85%; the middle value sits exactly at the limit.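

Compound 4, like compound 1, is recorded in this assay only as a limit and not as a number, so the step between these two compounds cannot be read. The compounds shown leave open whether chloro in place of hydrogen on an aromatic carbon changes the activity at all.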